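Trimming a Methoxy Group on a Hydroxamate Series

The source may report more compounds than this note shows. Statements on the series, on what has been measured and on what is new or still open speak of the compounds shown alone.

Compound 1 `COc1ccc(C(=O)c2ccc3c(ccn3S(=O)(=O)c3ccc(/C=C/C(=O)NO)cc3)c2)cc1` in an assay on isolated protein for inhibition of histone deacetylase 8 (Homo sapiens) (a lower number here means a stronger inhibitor, a higher number a weaker inhibitor), gives 10000 nM.
Compound 2 `COc1ccc(C(=O)c2ccc3c(ccn3Cc3ccc(C(=O)NO)cc3)c2)cc1OC` in this assay gives 756 nM.
Compound 3 `COc1cccc(C(=O)c2ccc3c(ccn3S(=O)(=O)c3cccc(/C=C/C(=O)NO)c3)c2)c1` in this assay gives 3530 nM.

Compound 2 shows the lowest number of the three, with compound 3 nearest and compound 1 furthest, both gaps beyond the scatter. Compound 4 `COc1ccc(C(=O)c2ccc3c(ccn3Cc3ccc(C(=O)NO)cc3)c2)cc1` is not yet measured. It differs from compound 2 in one place: hydrogen in place of methoxy on an aromatic carbon, which at a wider view reads 3,4-dimethoxyphenyl to 4-methoxyphenyl. Among the measured compounds shown here, no measured pair isolates this change, so nothing on the shared core speaks directly to it. A step of a 1.2-fold higher number from compound 2 to compound 4 (0.08 log units; within the scatter) is expected, staying within the scatter or slightly weaker. Compound 4 is estimated at 900 nM, between 400 nM and 2500 nM.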

Compound 4, half-maximal inhibitory concentration: 646 nM
Beside the measured number, compound 4's estimate is 1.4-fold (0.14 log units) above it; the measured number falls inside the stated range.
By their numbers in this assay, from the lowest: compounds 4 and 2 (each within the scatter of the next); then compound 3; then compound 1.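

In this assay, among the compounds shown here, hydrogen in place of methoxy, on the aromatic carbon ortho to a methoxy group, gives a 1.2-fold lower number from compound 2 to compound 4 (0.07 log units; within the scatter) and so offers the first direct reading of this position. The 3,4-dimethoxyphenyl and 4-methoxyphenyl forms cannot be told apart here, so this methoxy group is not needed to keep the number of compound 2. No supporting data explain this result.

As far as these compounds go, whether an amine, a carboxylic acid or a longer chain would be accommodated at this position remains open. So does the effect of replacing the other methoxy group on the ring.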